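This account rests on a few compounds, and the source may have more. Where it says the series, first, only, none or still open, it means among the compounds named here.

Measured so far in an assay (Rattus norvegicus) for inhibition of Fatty-acid amide hydrolase 1 (Homo sapiens); on this read-out higher numbers stand for weaker inhibition and lower numbers for stronger inhibition:
compound 1 `Nc1ccc(-c2cnc(C(=O)CCCCCCc3ccccc3)o2)cc1` gives 90 nM;
compound 2 `O=C(O)c1ccc(-c2cnc(C(=O)CCCCCCc3ccccc3)o2)cc1` gives 60 nM;
compound 3 `O=C(CCCCCCc1ccccc1)c1ncc(-c2ccncn2)o1` gives 2.3 nM.

Compound 2 stands second highest of the three numbers; its nearest neighbour is compound 1, within the scatter, and its furthest is compound 3, beyond it. Compound 4 `CN1CCN(C(=O)c2cnc(C(=O)CCCCCCc3ccccc3)o2)CC1` is not yet measured. The change from compound 2 is (4-methylpiperazin-1-yl)carbonyl in place of 4-carboxyphenyl on an aromatic carbon. The measured steps bear on it only in part. a 1.5-fold lower number from compound 1 to compound 2 (0.18 log units; within the scatter) shows that swapping the group on the phenyl ring leaves the number where it was. a 39-fold lower number from compound 1 to compound 3 (1.59 log units; beyond the scatter) and a 26-fold lower number from compound 2 to compound 3 (1.42 log units; beyond the scatter) show that swapping the whole ring for pyrimidin-4-yl lowers the number strongly. Among the measured compounds shown here, no step covers replacing the ring by a (4-methylpiperazin-1-yl)carbonyl, so in this assay no step beyond the scatter is expected in either direction, with wide uncertainty. Compound 4 is estimated at 120 nM (range 25 nM to 600 nM), expected to mean a 2.0-fold higher number from compound 2 to compound 4 (0.30 log units; within the scatter).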

Compound 4, inhibition constant: 80 nM
Compound 4: middle estimate off by 1.5-fold (0.18 log units), on the high side; measured number inside the range.
By their numbers in this assay, from the lowest: compound 3; then compounds 2, 4 and 1 (each within the scatter of the next).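

In this assay, a (4-methylpiperazin-1-yl)carbonyl, with its non-aromatic ring, on this aromatic carbon next to the ring oxygen matches both substituted phenyl groups (a 1.3-fold higher number from compound 2 to compound 4 (0.12 log units; within the scatter); a 1.1-fold lower number from compound 1 to compound 4 (0.05 log units; within the scatter)). Pyrimidin-4-yl alone stays apart (a 35-fold higher number from compound 3 to compound 4 (1.54 log units; beyond the scatter)), so compound 3 is the one exception among groups that otherwise give numbers within the scatter of each other. Nothing available gives a reason for this pattern. Still open, on these data alone, is whether pyridin-2-yl would fall with compound 3 or with compounds 1, 2 and 4, and where a carboxylic acid set directly on this carbon would fall.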